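Fluorine Added Again, This Time on a Weaker Core

A few compounds are considered here, and "the series" means these few. Any claim that something is new, unique, unknown or untested is made for them only; others in the source may bear on it.

Compound 1, `Fc1ccc(Nc2cc(Nc3ccc(Oc4ccncc4-c4cccnc4)c(F)c3)ncn2)cc1F`, gives 80 nM in a functional assay on MKN-45 cells (Homo sapiens) for cytotoxicity, read by MTT assay, with a stated time of 72 h; a higher number here means a weaker inhibitor, a lower number a stronger inhibitor.
Compound 2, `Fc1ccc(Nc2cc(Nc3ccc(Oc4ccncc4-c4cccnc4)c(F)c3)ncn2)cc1`, gives 160 nM in this assay.
Compound 3, `Cn1cc(-c2ccccc2)cc(C(=O)Nc2ccc(Oc3ccncc3-c3cccnc3)c(F)c2)c1=O`, gives 5400 nM in this assay.

Compound 1 and compound 2 share one core, while compound 3 is built on another; the difference between the two cores is not broken down here. In this assay compound 3 stands with the highest of the three numbers, and its gaps to compound 2 and to compound 1 are both beyond the usual scatter, so it is clearly the weakest of the three.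

Within the first core there is one measured step: a 2.0-fold lower number from compound 2 to compound 1 (0.30 log units; within the scatter), the change being (fluoro in place of hydrogen on an aromatic carbon).

Compound 4, `Cn1cc(-c2ccc(F)cc2)cc(C(=O)Nc2ccc(Oc3ccncc3-c3cccnc3)c(F)c2)c1=O`, has not been measured yet. It differs from compound 3 by fluoro in place of hydrogen on an aromatic carbon. The place is not quite the same as before: in compound 1 the new fluoro sits ortho to a fluoro group and meta to a large group, whereas in compound 4 it sits para to a large group. It is therefore the same kind of change, not the same one.

For the measured compounds named here, the only guide is the earlier step, which lay within the scatter, so in this assay the step from compound 3 to compound 4 is expected to be small, a 1.5-fold lower number from compound 3 to compound 4 (0.19 log units; within the scatter), resting on a 2.0-fold lower number from compound 2 to compound 1 (0.30 log units; within the scatter). Compound 4 is accordingly estimated at 3500 nM, likely between 1500 nM and 8000 nM.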

Compound 4, half-maximal inhibitory concentration: 7100 nM
Compound 4: middle estimate off by 2.0-fold (0.31 log units), on the low side; the range from low to high includes it.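

In this assay, going from phenyl to 4-fluorophenyl on the core of compound 3 gives a 1.3-fold higher number from compound 3 to compound 4 (0.12 log units; within the scatter), so this single fluoro leaves no readable mark on that core. Set beside the earlier fluoro step on the other core, the new step does not stand apart from it, and the two cores cannot be told apart on this evidence: the same change on two cores in this assay, a 2.0-fold lower number (0.30 log units; within the scatter) from compound 2 to compound 1 and a 1.3-fold higher number (0.12 log units; within the scatter) from compound 3 to compound 4, 2.6-fold (0.42 log units) apart, within the scatter of two such steps. For the compounds shown here, this shows only that the change stayed small on both cores, since neither step rises above the noise of repeat measurements; it does not show that the change carries over with the same size or direction, as there are only two pairs, the fluoro does not sit in the same place in them, and a modest real difference between the cores could be hidden in the scatter.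

The compounds shown leave open whether a larger or quite different group in place of that hydrogen on the phenyl of compound 3, such as a methoxy group, an amine or a carboxylic acid, would move the number beyond the scatter. They also leave open whether such a group would behave alike on the core of compound 1 and on the core of compound 3.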